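The source may report more compounds than this note shows. Statements on the series, on what has been measured and on what is new or still open speak of the compounds shown alone.

Of the compounds shown here, three have so far been tested in a functional assay on the whole organism for antagonist activity, with Rattus norvegicus as the target; on this read-out lower numbers stand for an effect already at smaller amounts and higher numbers for an effect only at larger amounts of compound. Compound 1 `CCN(C)c1ncnc2c1ncn2CC1CC1` gives 12.5 mg/kg in this assay, and compound 2 `CCNc1ncnc2c1ncn2CC1CC1` gives 22 mg/kg. These two differ in one place only, (methyl in place of hydrogen on a nitrogen on an aromatic ring), and that change made a step of a 1.8-fold lower number from compound 2 to compound 1 (0.25 log units; within the scatter). Compound 3 `Nc1nc(NC2CC2)c2ncn(CC3CC3)c2n1` rests on another core; the difference between the two cores of compound 2 and compound 3 is not broken down here. In this assay compound 3 gives 9 mg/kg. Compound 4 `CNc1nc(NC2CC2)c2ncn(CC3CC3)c2n1` has not yet been measured and differs from compound 3 by methyl in place of hydrogen on a nitrogen on an aromatic ring. For the measured compounds named here, this is the same kind of change as the one from compound 2 to compound 1, not the same: there the nitrogen's other neighbours were aromatic carbon and saturated chain carbon, here the other neighbour is aromatic carbon only. Resting on the earlier step of a 1.8-fold lower number from compound 2 to compound 1 (0.25 log units; within the scatter), the expected step is a 1.3-fold lower number from compound 3 to compound 4 (0.11 log units; within the scatter). Compound 4 is therefore estimated at 7 mg/kg, most likely between 3.5 mg/kg and 14 mg/kg.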

Compound 4, dose for half-maximal effect: 3 mg/kg
Beside the measured number, compound 4's estimate is 2.3-fold (0.37 log units) above it; measured number below the stated range.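

In this assay, methyl in place of hydrogen on the amino nitrogen gave a 3.0-fold lower number from compound 3 to compound 4 (0.48 log units; beyond the scatter). Set beside the earlier step on the other core, the size of this step cannot be told apart from it: the same change on two cores in this assay, a 1.8-fold lower number (0.25 log units; within the scatter) from compound 2 to compound 1 and a 3.0-fold lower number (0.48 log units; beyond the scatter) from compound 3 to compound 4, 1.7-fold (0.23 log units) apart, within the scatter of two such steps Both steps point the same way, so the change carried over in direction, but two cores cannot establish a rule for the series, and the earlier step taken alone lies within the scatter.

The compounds shown leave open whether a longer chain, such as propyl, or an acetyl group on this nitrogen would give a lower or a higher number. They also leave open whether methyl would give a similar step on any further core.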